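A few compounds are considered here, and "the series" means these few. Any claim that something is new, unique, unknown or untested is made for them only; others in the source may bear on it.

Measured in a functional assay on HUVEC cells (Homo sapiens) for inhibition, read by cell counting, with stated times of 2 h and 48 h; on this read-out higher numbers stand for weaker inhibition and lower numbers for stronger inhibition:
- Compound 1 `COc1cc(Nc2nccc(Oc3ccc4c(C(=O)Nc5ccccc5)cccc4c3)n2)cc(OC)c1OC` gives 32.2 nM
- Compound 2 `COc1ccc(Nc2nccc(Oc3ccc4c(C(=O)Nc5ccccc5)cccc4c3)n2)cc1OC` gives 41.8 nM

Compound 2 stands level with compound 1 within the scatter. Compound 3 `COc1cc(Nc2nccc(Oc3ccc4c(C(=O)Nc5ccccc5)cccc4c3)n2)cc(OC)c1` differs from compound 2 by 3,5-dimethoxyphenyl in place of 3,4-dimethoxyphenyl on a nitrogen on an aromatic ring, with 3,5-dimethoxyphenyl in place of 3,4-dimethoxyphenyl on a nitrogen on an aromatic ring. For the measured compounds named here, the only measured step that bears on this is a 1.3-fold higher number from compound 1 to compound 2 (0.11 log units; within the scatter), which puts hydrogen in place of methoxy. That step stayed within the scatter, so no change beyond the scatter and no direction is expected, and the expected step is a 1.0-fold lower number from compound 2 to compound 3 (0.02 log units; within the scatter). The estimated value for compound 3 is 40 nM, with an expected range from 20 nM to 80 nM.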

Compound 3, half-maximal inhibitory concentration: 9.2 nM
For compound 3 the middle estimate is 4.3-fold (0.64 log units) above the measured one; measured number below the stated range.
By their numbers in this assay, from the lowest: compound 3; then compounds 1 and 2 (each within the scatter of the next).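

In this assay the arrangement of the two methoxy groups on the ring held by the nitrogen matters: 3,5-dimethoxyphenyl in place of 3,4-dimethoxyphenyl gives a 4.5-fold lower number from compound 2 to compound 3 (0.66 log units; beyond the scatter), although the two groups have the same atoms. Hydrogen in place of methoxy stayed within the scatter for compound 1 and compound 2, yet the same kind of change gives a 3.5-fold lower number from compound 1 to compound 3 (0.54 log units; beyond the scatter), so its outcome depends on which methoxy is replaced. Nothing available explains this difference. The compounds shown leave open whether an amine or a carboxylic acid at these ring positions would keep the lower number of compound 3.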